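Capping the Amino Group: From Compound 3 to Compound 4

The compounds below may be only part of what the source reports. "The series", "measured", "known", "first", "only" and "open" are said of these compounds alone.

Compound 1 `Nc1ncnc2c1ccn2-c1ccc(NC(=O)Nc2ccc(Cl)c(C(F)(F)F)c2)cc1` gives 8100 nM
Compound 2 `Nc1ncnc2c1ccn2-c1ccc(NC(=O)Nc2cc(C(F)(F)F)cc(C(F)(F)F)c2)cc1` gives 3000 nM
Compound 3 `Nc1ncnc2c1ccn2-c1ccc(NC(=O)Nc2ccc(Cl)c(Cl)c2)cc1` gives 5400 nM

These three compounds share one core and differ only in the groups on the outer ring of the urea. In a functional assay on A375P cells (Homo sapiens) for antiproliferative activity, read by MTT assay, with a stated time of 24 h (a higher number here means a weaker inhibitor, a lower number a stronger inhibitor), compound 3 gives 5400 nM, the second highest of the three numbers. For the measured compounds named here, its nearest neighbour is compound 1, which in this assay gives 8100 nM, and the only single-point step measured so far, a 1.5-fold lower number from compound 1 to compound 3 (0.18 log units; within the scatter), lies within the scatter. Compound 2, with this assay giving 3000 nM, sits furthest from compound 3, yet that gap too is within the usual scatter, so no order among the three can be claimed.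

Compound 4 `O=C(Nc1ccc(-n2ccc3c(NC(=O)c4ccccc4)ncnc32)cc1)Nc1ccc(Cl)c(Cl)c1` takes a different direction. The change from compound 3 is benzoyl in place of hydrogen on a nitrogen on an aromatic ring; cut one bond further out, the same change reads amino to benzamido. Going by the values given here, no measured step touches this part of the molecule, since the one known step alters only the urea ring, so nothing measured bears directly on it. With no guidance, the expected step of a 1.5-fold higher number from compound 3 to compound 4 (0.17 log units; within the scatter) is modest and uncertain, and compound 4 is estimated at 8000 nM, within a range from 2000 nM to 30000 nM.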

Compound 4, half-maximal inhibitory concentration: 4000 nM
Beside the measured number, compound 4's estimate is 2.0-fold (0.30 log units) above it; low and high end bracket the measured number.
By their numbers in this assay, from the lowest: compounds 2, 4, 3 and 1 (each within the scatter of the next, the first and the last beyond it).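

Until this point, the only measured step sat on the outer ring of the urea; compound 4 is the first compound shown with a change on the amino group of the shared core. In this assay, placing benzoyl on that nitrogen gives a 1.4-fold lower number from compound 3 to compound 4 (0.13 log units; within the scatter), so this group of 8 heavy atoms, with its own six-membered aromatic ring, can replace a hydrogen here without moving the number beyond the scatter, and for this urea ring a free amino group is not needed to keep a reading of this size. Nothing measured on these compounds speaks to what lies behind this small step.

Going by these compounds, whether benzoyl on this nitrogen gives an equally small step when paired with the outer rings of compound 1 and compound 2 stays open. Also open, on these data alone, is what an acetyl group, a methyl group or a longer carbon chain on the same nitrogen would do, and so whether any group at this position can move the number beyond the scatter.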